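Swapping the Five-Membered Heteroaryl Arm: Thiazole to Imidazole

The source may report more compounds than this note shows. Statements on the series, on what has been measured and on what is new or still open speak of the compounds shown alone.

Compound 2 `CCc1nc(C)c(CN2CCN(c3cccc4[nH]c(-c5ccc(C(C)(C)C)cc5)nc34)CC2)s1` gives 120 nM in an assay on isolated protein for displacement of a labelled ligand from Gonadotropin-releasing hormone receptor (Rattus norvegicus); a higher number here means a weaker inhibitor, a lower number a stronger inhibitor. That is the lower of the two numbers recorded so far: compound 1 `Cc1nc(C)c(CN2CCN(c3cccc4[nH]c(-c5ccc(C(C)(C)C)cc5)nc34)CC2)o1` gives 740 nM in this assay, and the step of a 6.2-fold lower number from compound 1 to compound 2 (0.79 log units; beyond the scatter) lies beyond the usual scatter. Compound 3 `Cc1nc(CN2CCN(c3cccc4[nH]c(-c5ccc(C(C)(C)C)cc5)nc34)CC2)cn1C` has not yet been measured. It differs from compound 2 in one place: 1,2-dimethyl-1H-imidazol-4-yl in place of 2-ethyl-4-methyl-1,3-thiazol-5-yl on a saturated chain carbon bound to an amine nitrogen in a ring. For the measured compounds named here, the only measured step that bears on this change is the one between compound 1 and compound 2, where exchanging one five-membered heteroaryl group for another on the same saturated chain carbon moved the number by a 6.2-fold lower number from compound 1 to compound 2 (0.79 log units; beyond the scatter). Going by the values given here, with only two rings compared there is no way to tell whether the imidazole of compound 3 will read like the thiazole of compound 2 or like the oxazole of compound 1, so the estimate sits between them with a wide range. The step of a 3.3-fold higher number from compound 2 to compound 3 (0.52 log units; beyond the scatter) is therefore the expected outcome, a modest rise. In this assay compound 3 is expected at 400 nM, within 100 nM to 1500 nM.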

Compound 3, half-maximal inhibitory concentration: 34 nM
Estimate against measurement, compound 3: 12-fold (1.07 log units) above; the whole stated range lies above it.
By their numbers in this assay, from the lowest: compound 3; then compound 2; then compound 1.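

In this assay, the 1,2-dimethyl-1H-imidazol-4-yl group on this saturated chain carbon gives the lowest number of the three rings, with a 3.5-fold lower number from compound 2 to compound 3 (0.55 log units; beyond the scatter) and a 22-fold lower number from compound 1 to compound 3 (1.34 log units; beyond the scatter). For the compounds shown here, the earlier pair showed only that one five-membered heteroaryl group could read better than another; compound 3 shows that the thiazole of compound 2 does not mark the best reading at this position, and that a ring without sulfur or an ethyl group can go lower still. This single change alters the ring atoms, the point of attachment and the alkyl groups together, and no measurement shown explains why the number falls.

The compounds shown leave open which of those differences carries the step, since a 2-ethyl-1-methyl-1H-imidazol-4-yl group would be needed to separate the imidazole ring from its methyl group. They also leave open whether a five-membered ring is needed at all, a question that a six-membered pyridine ring on the same chain carbon would address.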